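The source may hold more compounds than are shown below. What is called first, only, known or untested is meant among the compounds shown, and "the series" means these compounds.

Values so far in a functional assay on HeLa cells (Homo sapiens) for inhibition, read by MTT assay, with a stated time of 48 h; a higher number here means a weaker inhibitor, a lower number a stronger inhibitor 
- Compound 1 `Brc1ccc2[nH]cc(C(c3ccccc3)c3c[nH]c4ccc(Br)cc34)c2c1` gives 900 nM 
- Compound 2 `O=[N+]([O-])c1ccc(C(c2c[nH]c3ccc(Br)cc23)c2c[nH]c3ccc(Br)cc23)cc1` gives 1500 nM 

Going by the values given here, compound 2 at 1500 nM stands level with compound 1, the only other compound measured. Among the compounds with values here, the single measured step (a 1.7-fold higher number from compound 1 to compound 2 (0.22 log units; within the scatter)) comes from nitro in place of hydrogen on an aromatic carbon, and it lies within the scatter.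

Compound 3 `CCCCCCCC(c1c[nH]c2ccc(Br)cc12)c1c[nH]c2ccc(Br)cc12` brings a different kind of change: heptyl in place of 4-nitrophenyl on a saturated chain carbon bound to two aromatic carbons. Within the data shown here, the measured step is the only guide here, and it is a weak one. Among the measured compounds shown here, compound 1 and compound 2 both keep an aromatic ring at that carbon, and no measured compound carries a chain there. The step to compound 2 (a 1.7-fold higher number from compound 1 to compound 2 (0.22 log units; within the scatter)) stayed within the scatter and points in no clear direction, so no shift beyond the scatter is expected in this assay. The expected step is small (a 1.2-fold lower number from compound 2 to compound 3 (0.06 log units; within the scatter)). For compound 3 the estimated value is 1300 nM with a wide expected range (400 nM to 5000 nM).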

Compound 3, half-maximal inhibitory concentration: 1300 nM
Compound 3: the middle estimate sits on the measured number at the digits printed; the range from low to high includes it.
By their numbers in this assay, from the lowest: compounds 1, 3 and 2 (each within the scatter of the next).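

Compound 1 and compound 2 showed only that a substituent on an aromatic ring at this carbon made no readable difference; compound 3 tests a far larger change, removing the ring from this position altogether. In this assay, replacing 4-nitrophenyl with heptyl gives a 1.2-fold lower number from compound 2 to compound 3 (0.06 log units; within the scatter), and replacing phenyl with heptyl gives a 1.4-fold higher number from compound 1 to compound 3 (0.16 log units; within the scatter), so on a saturated chain carbon bound to two aromatic carbons, a ring is not required for a value in the range of these three compounds, and heptyl, with no ring and no hydrogen-bond acceptors, cannot be told apart from either aromatic group. Nothing available on these compounds bears on why such different groups read alike in this cell assay.

As far as these compounds go, whether this tolerance has a limit stays open, since a much shorter chain such as methyl, a longer chain, or a heptyl chain ending in an amine or a carboxylic acid might give a value beyond the scatter. All three compounds also share the same core, so what the bromine atoms on it contribute cannot be judged from these results.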